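The source may report more compounds than this note shows. Statements on the series, on what has been measured and on what is new or still open speak of the compounds shown alone.

Values in an ADME assay on GES1 cells (Homo sapiens) for inhibition, read by MTT assay, with a stated time of 72 h; a lower number here means a stronger inhibitor, a higher number a weaker inhibitor:
compound 1 `Cc1cc(Nc2cc(-c3ccccc3)[nH]n2)n2nc(SCc3ccc(Br)cc3)nc2n1` gives 39300 nM
compound 2 `C=CCSc1nc2nc(C)cc(Nc3cc(-c4ccccc4)[nH]n3)n2n1` gives > 50000 nM (a limit)
compound 3 `CCCSc1nc2nc(C)cc(Nc3cc(-c4ccccc4)[nH]n3)n2n1` gives > 50000 nM (a limit)

Compound 3 has no number in this assay, only a limit, and the same holds for compound 2. Both sit at the limit of > 50000 nM in this assay, at which 2 of the 3 values shown sit.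

Compound 4 `Cc1cc(Nc2cc(-c3ccccc3)[nH]n2)n2ncnc2n1` differs by hydrogen in place of propylsulfanyl on an aromatic carbon, which is hydrogen in place of propylsulfanyl on an aromatic carbon. Among the compounds with values here, no measured step removes the sulfur-linked group altogether, so the evidence is indirect. Changing that group gave an at least 1.2-fold higher number from compound 1 to compound 2 (0.10 log units; that floor lies within the scatter) and an at least 1.2-fold higher number from compound 1 to compound 3 (0.10 log units; that floor lies within the scatter), with both floors within the scatter. The remaining comparison is a step that the two limits leave unreadable from compound 2 to compound 3, so it adds no size. These steps give no sign of a large change, and no step beyond the scatter is expected in this assay, in either direction.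

The expected step is a number no higher from compound 3 to compound 4 (the limit leaves the size open).

For compound 4 the estimated value is 50000 nM, with an expected range from 25000 nM to 100000 nM.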

Compound 4, half-maximal inhibitory concentration: > 50000 nM
Compound 4 gave a limit, no number (the forecaster's own chance of this, stated with the estimate: 70%); the middle value lies on the limit itself.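

In this assay, the sulfur-linked group is now removed altogether, and compound 4 also gives only a limit, not a number. Hydrogen in place of (4-bromobenzyl)sulfanyl gives an at least 1.2-fold higher number from compound 1 to compound 4 (0.10 log units; that floor lies within the scatter), so even complete loss of the group shows no step beyond the scatter. The steps to compound 4 from compound 2 and from compound 3 cannot be read, because these values share one limit: the limit of > 50000 nM in this assay, at which 3 of the 4 values shown sit.

On these data alone, whether any group on this aromatic carbon can move the number beyond the scatter remains open, and compound 1 alone gives a number to compare against. An amine or a carboxylic acid in place of the sulfur-linked group would test this position with groups unlike the sulfur-linked chains and the hydrogen shown here.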